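Acyl chloride in place of fluoro on the anilide ring

This account rests on a few compounds, and the source may have more. Where it says the series, first, only, none or still open, it means among the compounds named here.

Of the compounds shown here, two have been measured in an in vitro assay on BTI-TN-5B1-4 cells for inhibition of Amine oxidase [flavin-containing] A (Homo sapiens), read by fluorescence; a lower number here means a stronger inhibitor, a higher number a weaker inhibitor. Compound 1 `CCOC(=O)c1ccc(NC(=O)c2cc3ccccc3oc2=O)cc1` gives 16000 nM, and compound 2 `O=C(Nc1ccc(F)cc1)c1cc2ccccc2oc1=O` gives 13100 nM. The step of a 1.2-fold lower number from compound 1 to compound 2 (0.09 log units; within the scatter) is the only one recorded. Compound 2 thus has the lowest of the two numbers, but its gap to compound 1 is within the scatter, so no order between them can be claimed.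

Compound 3 `O=C(Cl)c1ccc(NC(=O)c2cc3ccccc3oc2=O)cc1` is unmeasured. Its difference from compound 2 is a group of 3 heavy atoms (1 carbon, 1 oxygen, 1 chlorine; no ring) in place of one fluorine atom, on an aromatic carbon. Among the measured compounds shown here, the one step that bears on this position, a 1.2-fold lower number from compound 1 to compound 2 (0.09 log units; within the scatter), exchanged one group for another without a change beyond the scatter; compound 1 already carries a carbonyl-bearing group at the same place. On that basis no change beyond the scatter is expected in this assay, and compound 3 is estimated at 15000 nM, with a range from 6000 nM to 40000 nM, which means an expected step of a 1.1-fold higher number from compound 2 to compound 3 (0.06 log units; within the scatter).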

Compound 3, half-maximal inhibitory concentration: 9670 nM
Estimate against measurement, compound 3: 1.6-fold (0.19 log units) above, and the stated range covers the measured number.
By their numbers in this assay, from the lowest: compounds 3, 2 and 1 (each within the scatter of the next).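

In this assay the exchange of fluoro for the acyl chloride gives a 1.4-fold lower number from compound 2 to compound 3 (0.13 log units; within the scatter) and so adds a larger group with a carbonyl to the groups read at this aromatic carbon. The carbonyl-bearing group is now varied at its own carbonyl carbon as well, where chloro in place of ethoxy gives a 1.7-fold lower number from compound 1 to compound 3 (0.22 log units; within the scatter) and again stays inside the scatter. The three groups at this place therefore cannot be ordered, and no independent data bear on the result.

Still open, as far as these compounds go, is whether an amine or a carboxylic acid on the same aromatic carbon would move the number beyond the scatter. From the compounds shown here alone, the shared core is the same in all three compounds, so the effect of a methoxy group placed on it also remains open.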